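The compounds below may be only part of what the source reports. "The series", "measured", "known", "first", "only" and "open" are said of these compounds alone.

Compound 1 `COc1cc([C@H]2C[C@]2(CO)C(=O)Nc2ccccc2Cl)cc(OC)c1OC`: in a functional assay on A549 cells (Homo sapiens) for cytotoxicity, read by MTT assay, with a stated time of 48 h (on this read-out lower numbers stand for stronger inhibition and higher numbers for weaker inhibition), compound 1 gives 36700 nM.
Compound 2 `CCOC(=O)[C@@]1(C(=O)Nc2ccccc2Cl)C[C@H]1c1cc(OC)c(OC)c(OC)c1`: in this assay compound 2 gives 17600 nM.
Compound 3 `COc1cc([C@H]2C[C@]2(CO)C(=O)Nc2ccccc2)cc(OC)c1OC`: in this assay compound 3 gives only a limit of the assay, > 100000 nM.

Of the two compounds with a number, compound 2 gives the lower one and compound 1 the higher one, and the two sit beyond the usual scatter of each other. The difference between the two cores is not broken down here.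

From compound 1 to compound 3 a single change is made: hydrogen in place of chloro on an aromatic carbon. It brought an at least 2.7-fold higher number from compound 1 to compound 3 (0.43 log units; beyond the scatter). The value of compound 3 sits at the limit of > 100000 nM in this assay, at which 1 of the 3 values shown sits.

Compound 4 `CCOC(=O)[C@@]1(C(=O)Nc2ccccc2)C[C@H]1c1cc(OC)c(OC)c(OC)c1` has not yet been measured in this assay. It stands to compound 2 as compound 3 stands to compound 1: hydrogen in place of chloro on an aromatic carbon. The place of the change is described in the same words for both pairs, so this is the same change made on the other core.

Compound 4 is therefore expected to give a weaker inhibition than compound 2, a step of a 3.1-fold higher number from compound 2 to compound 4 (0.49 log units; beyond the scatter), resting on the earlier step of an at least 2.7-fold higher number from compound 1 to compound 3 (0.43 log units; beyond the scatter). The estimate for compound 4 in this assay is 55000 nM, with a range from 28000 nM to 150000 nM, and it may well come back as only a limit of the assay.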

Compound 4, half-maximal inhibitory concentration: 65900 nM
For compound 4 the middle estimate is 1.2-fold (0.08 log units) below the measured one; the measured number falls inside the stated range.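

In this assay, putting hydrogen in place of chloro on the second core brings a 3.7-fold higher number from compound 2 to compound 4 (0.57 log units; beyond the scatter), so the drop in inhibition seen on the core of compound 1 also appears on this core. The change therefore points the same way on both cores, and this is the main thing the new value shows, but how closely the two step sizes agree remains unsettled: the same change on two cores in this assay, an at least 2.7-fold higher number (0.43 log units; beyond the scatter) from compound 1 to compound 3 and a 3.7-fold higher number (0.57 log units; beyond the scatter) from compound 2 to compound 4; the limit leaves it open whether they differ Compound 3 gives only a limit of the assay, > 100000 nM, and agreement in direction on two cores says nothing about whether the change would carry over to any other core in the series.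

The compounds shown hold only chloro or hydrogen in this place, so it remains open whether a fluoro, methyl or methoxy group there would match chloro or fall closer to hydrogen. From the compounds shown here alone, it also remains open whether the same step would appear if the hydroxymethyl or ethyl ester group gave way to a carboxylic acid or an amine.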